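Compound 3 to Compound 4: an Exchange on the Side Chain

The compounds below may be only part of what the source reports. "The series", "measured", "known", "first", "only" and "open" are said of these compounds alone.

Compound 3 `CCOC(=O)CN1CCN(c2c(F)cc3c(=O)c(C(=O)O)cn(C4CC4)c3c2OC)CC1C` stands highest of the three numbers in an ADME assay on Vero cells (Chlorocebus sabaeus) for cytotoxicity, read by MTT assay, with a stated time of 72 h (on this read-out higher numbers stand for lower toxicity in this test and lower numbers for higher toxicity in this test), giving 1000 ug/mL. Its nearest neighbour is compound 2 `COC(=O)CN1CCN(c2c(F)cc3c(=O)c(C(=O)O)cn(C4CC4)c3c2OC)CC1C`, which gives 500 ug/mL; the furthest is compound 1 `COc1c(N2CCN(CC#N)C(C)C2)c(F)cc2c(=O)c(C(=O)O)cn(C3CC3)c12`, which gives 354 ug/mL. The step of a 2.8-fold higher number from compound 1 to compound 3 (0.45 log units; beyond the scatter) is modest, while a 2.0-fold higher number from compound 2 to compound 3 (0.30 log units; within the scatter) stays within the scatter. Compound 4 `CO/N=C(\C)CN1CCN(c2c(F)cc3c(=O)c(C(=O)O)cn(C4CC4)c3c2OC)CC1C` differs from compound 3 by a group of 5 heavy atoms (3 carbon, 1 nitrogen, 1 oxygen; no ring) in place of a group of 5 heavy atoms (3 carbon, 2 oxygen; no ring), on a saturated chain carbon bound to an amine nitrogen in a ring. Going by the values given here, the steps that bear on this exchange, a 1.4-fold higher number from compound 1 to compound 2 (0.15 log units; within the scatter) and a 2.8-fold higher number from compound 1 to compound 3 (0.45 log units; beyond the scatter), each replaced a group at this same carbon and moved the number only a little. The expected step is therefore small, a 1.4-fold lower number from compound 3 to compound 4 (0.15 log units; within the scatter), and no larger than the scatter in either direction. Compound 4 is accordingly estimated at 700 ug/mL, with a range from 300 ug/mL to 1500 ug/mL.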

Compound 4, half-maximal cytotoxic concentration: 49.6 ug/mL
Compound 4: the middle estimate sits 14-fold (1.15 log units) above what was measured; measured number below the stated range.
By their numbers in this assay, from the lowest: compound 4; then compounds 1, 2 and 3 (each within the scatter of the next, the first and the last beyond it).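

At this saturated chain carbon bound to an amine nitrogen in a ring, the nitrile and the two esters differed only modestly in this assay, but the new group gives a 20-fold lower number from compound 3 to compound 4 (1.30 log units; beyond the scatter) and a 10-fold lower number from compound 2 to compound 4 (1.00 log units; beyond the scatter) and a 7.1-fold lower number from compound 1 to compound 4 (0.85 log units; beyond the scatter) in a single exchange. The counted features of ethoxycarbonyl and the entering group match in heavy atoms, double bonds outside aromatic rings and hydrogen-bond acceptors, so those counts do not separate compound 3 from compound 4. No measurement here accounts for the drop.

Which part of the entering group goes with the lower number remains open. So does whether a ketone or an amide at this carbon would stay near compound 3 or fall near compound 4.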